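The source may hold more compounds than are shown below. What is called first, only, known or untested is meant among the compounds shown, and "the series" means these compounds.

Of the compounds shown here, three carrying the same core have been measured in an assay on tissue (A-431 cells) for inhibition of Indoleamine 2,3-dioxygenase 1 (Homo sapiens), with a stated time of 24 h; on this read-out lower numbers stand for stronger inhibition and higher numbers for weaker inhibition. Compound 1 `O=C(SCCO)SCc1ccc(Cl)cc1Cl` gives 390 nM, compound 2 `O=C(SCCc1cccc(O)c1)SCc1ccc(Cl)cc1Cl` gives 440 nM, and compound 3 `O=C(SCCc1ccc(O)cc1)SCc1ccc(Cl)cc1Cl` gives 400 nM. Compound 3 thus stands second highest of the three numbers, yet all three lie within the scatter of one another, so no order among them can be read.

Compound 4 `O=C(SCCc1ccc(CO)cc1)SCc1ccc(Cl)cc1Cl` is the next step from compound 3: hydroxymethyl in place of hydroxy on an aromatic carbon. The change sits on an aromatic carbon of a six-membered aromatic ring of carbon only, para to a large group. The measured steps that bear on it are a 1.0-fold higher number from compound 1 to compound 3 (0.01 log units; within the scatter) and a 1.1-fold lower number from compound 2 to compound 3 (0.04 log units; within the scatter); both show that moving or rearranging the hydroxy group left this assay essentially unchanged. Because of a 1.0-fold higher number from compound 1 to compound 3 (0.01 log units; within the scatter), a further small shift of the hydroxy is expected to produce no step beyond the scatter, and no change at the digits printed from compound 3 to compound 4 (within the scatter) is therefore the expected outcome. Compound 4 is estimated at 400 nM, with a likely range from 200 nM to 800 nM.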

Compound 4, half-maximal inhibitory concentration: 270 nM
Compound 4: the middle estimate sits 1.5-fold (0.17 log units) above what was measured, within the range that was stated.
By their numbers in this assay, from the lowest: compounds 4, 1, 3 and 2 (each within the scatter of the next).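

Putting hydroxymethyl in place of hydroxy on this aromatic carbon gives a 1.5-fold lower number from compound 3 to compound 4 (0.17 log units; within the scatter) in this assay, so no effect of the change can be read. The earlier compounds shown here varied only where the hydroxy stood, whereas this one adds a carbon between the ring and the hydroxy, keeping the same count of hydrogen-bond donors and acceptors, and the result shows that this larger group still leaves the step within the scatter. Nothing available here bears on why the number falls where it does.

From the compounds shown here alone, it remains open whether a carboxylic acid, an amine or a longer chain ending in hydroxy at this carbon would give a step beyond the scatter. Going by these compounds, it also remains open whether this carbon needs any oxygen-bearing group at all.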